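Trading an Aryl Amine for a Benzylamine

A few compounds are considered here, and "the series" means these few. Any claim that something is new, unique, unknown or untested is made for them only; others in the source may bear on it.

Of the compounds shown here, three built on one shared core have been tested in a functional assay on HeLa cells (Homo sapiens) for inhibition, read by sulforhodamine B assay; on this read-out lower numbers stand for stronger inhibition and higher numbers for weaker inhibition. Compound 1 `COc1cccc(NC2=CC(=O)c3c(nc4n3[C@H]3OC[C@@H](O)[C@H]3OC4)C2=O)c1` carries a 3-methoxyphenyl group on the amine nitrogen; in this assay compound 1 gives only a limit, > 8000 nM. Compound 2 `CCOc1ccc(NC2=CC(=O)c3c(nc4n3[C@H]3OC[C@@H](O)[C@H]3OC4)C2=O)cc1` carries a 4-ethoxyphenyl group in that place and gives 14400 nM. Compound 3 `Cc1ccc(NC2=CC(=O)c3c(nc4n3[C@H]3OC[C@@H](O)[C@H]3OC4)C2=O)cc1` carries a 4-methylphenyl group and gives 6590 nM, the lowest of the two numbers shown; its nearest neighbour is compound 2, and the step of a 2.2-fold lower number from compound 2 to compound 3 (0.34 log units; beyond the scatter) is modest but beyond the scatter. The step of an at least 1.2-fold lower number from compound 1 to compound 3 (0.08 log units; that floor lies within the scatter) cannot be sized fully because compound 1 sits at the limit (the limit of > 8000 nM in this assay, at which 1 of the 3 values shown sits).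

Compound 4 `O=C1C(NCc2ccccc2)=CC(=O)c2c1nc1n2[C@H]2OC[C@@H](O)[C@H]2OC1` is not yet measured. It differs from compound 3 in one place: benzyl in place of 4-methylphenyl on an amine nitrogen. Going by the values given here, every measured step here swaps one substituent on a phenyl ring for another while the ring stays bonded directly to the nitrogen; none inserts a carbon between nitrogen and ring, so no measured step gives the size or direction of this change. Among the compounds with values here, the numbers so far sit in a narrow, weak band, and with no guiding step the expected value for compound 4 is placed near that band, with a wide range and a real chance that only a limit is reported. Compound 4 is estimated at 9000 nM (between 2500 nM and 30000 nM), which would mean an expected step of a 1.4-fold higher number from compound 3 to compound 4 (0.14 log units; within the scatter).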

Compound 4, half-maximal inhibitory concentration: 11000 nM
Estimate against measurement, compound 4: 1.2-fold (0.09 log units) below; low and high end bracket the measured number.
By their numbers in this assay, from the lowest: compounds 3, 4 and 2 (each within the scatter of the next, the first and the last beyond it).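

The swap from (4-methylphenyl)amino to benzylamino keeps the same atoms but joins them differently, so the ring no longer sits directly on the amine nitrogen. Going by these compounds alone, this is the first change at this position that alters that link instead of a substituent on the ring, and in this assay the new benzyl compound shows two steps (a 1.7-fold higher number from compound 3 to compound 4 (0.22 log units; within the scatter)) and (a 1.3-fold lower number from compound 2 to compound 4 (0.12 log units; within the scatter)), both within the scatter, so these numbers do not separate the benzyl group from either directly bonded ring. The third step, to compound 4 from compound 1, cannot be read because compound 1 gives only a limit: the limit of > 8000 nM in this assay, at which 1 of the 4 values shown sits.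

Still open, from the compounds shown here alone, is whether a methoxy or ethoxy group on the benzyl ring would move the number beyond the scatter, as the swap of ethoxy for methyl did on the directly bonded ring (a 2.2-fold lower number from compound 2 to compound 3 (0.34 log units; beyond the scatter)). Also open, going by these compounds, is how this position would respond to a longer chain such as phenethyl, or to a group with no aromatic ring at all, such as morpholine.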